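Trifluoromethyl in place of fluorine on the arylidene ring

This account rests on a few compounds, and the source may have more. Where it says the series, first, only, none or still open, it means among the compounds named here.

Compound 2 `C=CCn1c(=O)/c(=C\c2cccc(F)c2)[nH]c(=O)/c1=C\c1ccccc1OC` and compound 3 `C=CCn1c(=O)/c(=C\c2ccccc2F)[nH]c(=O)/c1=C\c1ccccc1OC` share a core with compound 1 `COc1ccccc1/C=c1/[nH]c(=O)/c(=C\c2ccccc2OC)[nH]c1=O`. In a functional assay on MCF7 cells (Homo sapiens) for cytotoxicity, read by CCK-8 assay, with a stated time of 72 h (on this read-out lower numbers stand for stronger inhibition and higher numbers for weaker inhibition), compound 2 gives 13700 nM. Compound 3 gives 23000 nM, and the step of a 1.7-fold higher number from compound 2 to compound 3 (0.23 log units; within the scatter) stays within the scatter, so compound 2 and compound 3 cannot be told apart. Compound 1 is reported in this assay as "not active" (no number reported). Compound 4 `C=CCn1c(=O)/c(=C\c2ccccc2C(F)(F)F)[nH]c(=O)/c1=C\c1ccccc1OC` differs from compound 2 as follows: 2-(trifluoromethyl)phenyl in place of 3-fluorophenyl on a double-bonded chain carbon bound to an aromatic carbon. Within the data shown here, the only measured step on this ring, a 1.7-fold higher number from compound 2 to compound 3 (0.23 log units; within the scatter), was within the scatter, so moving a fluorine gave no change; a trifluoromethyl group is untested here, and compound 4 is therefore expected to give a 1.3-fold higher number from compound 2 to compound 4 (0.12 log units; within the scatter). The estimate for compound 4 is 18000 nM with a range of 6000 nM to 60000 nM.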

Compound 4, half-maximal inhibitory concentration: 6500 nM
Compound 4: the middle estimate sits 2.8-fold (0.44 log units) above what was measured; measured number inside the range.
By their numbers in this assay, from the lowest: compound 4; then compounds 2 and 3 (each within the scatter of the next).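

In this assay, the ring on the double-bonded chain carbon bound to an aromatic carbon now gives steps beyond the scatter: a 3.5-fold lower number from compound 3 to compound 4 (0.55 log units; beyond the scatter) for trifluoromethyl in place of fluoro on an aromatic carbon and a 2.1-fold lower number from compound 2 to compound 4 (0.32 log units; beyond the scatter) for the change from 3-fluorophenyl. Both steps are modest, but they show that this place can respond, which compound 2 and compound 3 alone did not show. Nothing available here accounts for these steps. Still open, from the compounds shown here alone, is whether a nitrile or an amine on this ring would match trifluoromethyl, and whether trifluoromethyl would hold this level where the fluorine of compound 2 sits.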